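Hydroxy in place of bromo: what the data allow to expect

This account rests on a few compounds, and the source may have more. Where it says the series, first, only, none or still open, it means among the compounds named here.

Three measured compounds share one core. Compound 1 `Cc1ccccc1-n1cc(CN2C(=O)C[C@@H]3CC[C@@]2(C)C3(C)C)nn1` gives 350 nM in a functional assay on SGC-7901 cells (Homo sapiens) for inhibition, read by MTT assay, with a stated time of 24 h (a higher number here means a weaker inhibitor, a lower number a stronger inhibitor), compound 2 `CC1(C)[C@H]2CC[C@]1(C)N(Cc1cn(-c3ccccc3Br)nn1)C(=O)C2` gives 500 nM, and compound 3 `CC1(C)[C@H]2CC[C@]1(C)N(Cc1cn(-c3ccc(Br)cc3)nn1)C(=O)C2` gives 450 nM. On the numbers shown, compound 3 stands within the scatter of both others: the steps were a 1.4-fold higher number from compound 1 to compound 2 (0.15 log units; within the scatter), a 1.3-fold higher number from compound 1 to compound 3 (0.11 log units; within the scatter) and a 1.1-fold lower number from compound 2 to compound 3 (0.05 log units; within the scatter). Compound 4 `CC1(C)[C@H]2CC[C@]1(C)N(Cc1cn(-c3ccc(O)cc3)nn1)C(=O)C2` differs from compound 3 by hydroxy in place of bromo on an aromatic carbon. Within the data shown here, none of the measured steps introduces a hydroxy, so they bear on this change only by showing that varying the group on the aromatic nitrogen has so far moved nothing beyond the scatter. A step of a 1.1-fold higher number from compound 3 to compound 4 (0.05 log units; within the scatter) in this assay is therefore expected, in no clear direction. Compound 4 is estimated at 500 nM, with a range from 200 nM to 1300 nM.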

Compound 4, half-maximal inhibitory concentration: 330 nM
For compound 4 the middle estimate is 1.5-fold (0.18 log units) above the measured one; measured number inside the range.
By their numbers in this assay, from the lowest: compounds 4, 1, 3 and 2 (each within the scatter of the next).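

In this assay, hydroxy in place of bromo, para to a large group, gives a 1.4-fold lower number from compound 3 to compound 4 (0.13 log units; within the scatter), so adding a hydrogen-bond donor and acceptor here moves the number no further than the scatter. The comparisons with the other aryl groups agree, with a 1.5-fold lower number from compound 2 to compound 4 (0.18 log units; within the scatter) and a 1.1-fold lower number from compound 1 to compound 4 (0.03 log units; within the scatter), which leaves all four compounds within the scatter of one another. No evidence is available that bears on this result. Still open, going by these compounds, is whether an amine, a carboxylic acid or a longer chain in place of hydroxy would produce a step beyond the scatter.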